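Aryl substituent changes on the ethenyl arm

The source may hold more compounds than are shown below. What is called first, only, known or untested is meant among the compounds shown, and "the series" means these compounds.

Three analogues share one core and differ only in the aryl group on the ethenyl arm. Compound 1 `COc1cc2nc(/C=C/c3ccncc3)nc(N3CCC(CCNS(N)(=O)=O)CC3)c2cc1OC` carries pyridin-4-yl and in an assay on cells for inhibition of Ectonucleotide pyrophosphatase/phosphodiesterase family member 1 (Homo sapiens), with a stated time of 60 min (a higher number here means a weaker inhibitor, a lower number a stronger inhibitor), compound 1 gives 218 nM. Compound 2 `COc1cc2nc(/C=C/c3ccccc3F)nc(N3CCC(CCNS(N)(=O)=O)CC3)c2cc1OC` carries 2-fluorophenyl; in this assay compound 2 gives 211 nM, and the step of a 1.0-fold lower number from compound 1 to compound 2 (0.01 log units; within the scatter) lies within the scatter. Compound 3 `COc1cc2nc(/C=C/c3cccc(F)c3)nc(N3CCC(CCNS(N)(=O)=O)CC3)c2cc1OC` carries 3-fluorophenyl; in this assay compound 3 gives 3580 nM, the highest number of the three, with the steps of a 16-fold higher number from compound 1 to compound 3 (1.22 log units; beyond the scatter) and a 17-fold higher number from compound 2 to compound 3 (1.23 log units; beyond the scatter) both large and beyond the scatter.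

Compound 4 `COc1cccc(/C=C/c2nc(N3CCC(CCNS(N)(=O)=O)CC3)c3cc(OC)c(OC)cc3n2)c1` keeps this arrangement and alters the substituent: methoxy in place of fluoro on an aromatic carbon. Within the data shown here, no measured pair exchanges fluoro for methoxy, so the measured steps only frame the question. They show that fluoro on the aromatic carbon meta to the large group is costly against compound 1 and compound 2, whereas 2-fluorophenyl is not. Whether methoxy at that place behaves as fluoro does there is not shown. The working expectation is that compound 4 remains close to compound 3, and a 1.2-fold lower number from compound 3 to compound 4 (0.08 log units; within the scatter) is expected to be small against the scatter. Compound 4 is therefore estimated at 3000 nM, within a range from 700 nM to 12000 nM.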

Compound 4, inhibition constant: 101 nM
For compound 4 the middle estimate is 30-fold (1.47 log units) above the measured one; measured number outside the range, below it.
By their numbers in this assay, from the lowest: compound 4; then compounds 2 and 1 (each within the scatter of the next); then compound 3.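

In this assay the aromatic carbon meta to a large group responds to which substituent it carries, not merely to being substituted: methoxy in place of fluoro gives a 35-fold lower number from compound 3 to compound 4 (1.55 log units; beyond the scatter) on otherwise identical structures. The 3-methoxyphenyl arm also separates from the two earlier arms, with a 2.1-fold lower number from compound 2 to compound 4 (0.32 log units; beyond the scatter) and a 2.2-fold lower number from compound 1 to compound 4 (0.33 log units; beyond the scatter) both modest, so compound 4 has the lowest number of the four and the high number of compound 3 belongs to 3-fluorophenyl rather than to this place as such. Nothing available here accounts for the gap between fluoro and methoxy on this carbon.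

Among the compounds shown, only fluoro and methoxy can be compared on this carbon, so it stays open whether a hydroxyl, an ethoxy group, an amine or a nitrile there would track methoxy, track fluoro or follow neither. On these data alone, it also stays open whether methoxy in place of fluoro would shift the number in the same direction on the 2-fluorophenyl arm, as compound 2 has no methoxy partner here.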